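Flexible Phenoxyethyl Chain in Place of Methylphenoxy

This account rests on a few compounds, and the source may have more. Where it says the series, first, only, none or still open, it means among the compounds named here.

Compound 1, `O=C(O)c1csc([C@H]2CC[C@@H]3[C@@H](/C=C/COc4ccccc4)[C@H](O)C[C@@H]3O2)n1`: in an assay on HEK293 cells for agonist activity at prostaglandin E2 receptor EP2 subtype (Homo sapiens), read by a beta-galactosidase reporter and beta-arrestin recruitment, with a stated time of 90 min (on this read-out higher numbers stand for an effect only at larger amounts of compound and lower numbers for an effect already at smaller amounts), compound 1 gives > 10000 nM, a limit of the assay rather than a number.
Compound 2, `O=C(O)c1csc([C@H]2CC[C@@H]3[C@@H](COc4ccc(OC(F)(F)F)cc4)[C@H](O)C[C@@H]3O2)n1`: in this assay compound 2 gives 4500 nM.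
Compound 3, `Cc1ccc(OC[C@@H]2[C@H]3CC[C@H](c4nc(C(=O)O)cs4)O[C@H]3C[C@H]2O)cc1`: in this assay compound 3 gives > 10000 nM, again a limit of the assay.

Compound 3 therefore stands at the upper edge of what this assay reports, and it shares this position with compound 1, as the limit of > 10000 nM in this assay, at which 2 of the 3 values shown sit, shows. Only compound 2 gives a real number. Among the compounds with values here, the single measured step, an at least 2.2-fold higher number from compound 2 to compound 3 (0.34 log units; beyond the scatter), concerns a substituent on the aromatic ring.

Compound 4, `O=C(O)c1csc([C@H]2CC[C@@H]3[C@@H](CCCOc4ccccc4)[C@H](O)C[C@@H]3O2)n1`, differs from compound 3 by 2-phenoxyethyl in place of 4-methylphenoxy on a saturated chain carbon bound to a saturated ring carbon. This change does not touch the aromatic substituent but the link between ring and core, so the measured step bears on it only loosely. Within the data shown here, the closest measured point of reference is compound 1, which also sits at the limit, though no step between compound 1 and compound 4 has been measured.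

For compound 4 the expectation is a value again at or near the limit, estimated at 15000 nM with a range from 4000 nM to 60000 nM. Compared with compound 3 this estimate corresponds to an expected step that the limit leaves unreadable from compound 3 to compound 4.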

Compound 4, half-maximal effective concentration: > 10000 nM
Compound 4: a limit, no number; the forecaster's own chance of this, stated with the estimate: 70%; the middle value does not contradict the limit.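

In this assay compound 4 gives > 10000 nM, a limit of the assay and not a number. Compound 3 also sits at a limit, so no step can be read between compound 3 and compound 4: the limit of > 10000 nM in this assay, at which 3 of the 4 values shown sit. The compounds shown leave open whether 2-phenoxyethyl and 4-methylphenoxy differ at all in this assay.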